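A few compounds are considered here, and "the series" means these few. Any claim that something is new, unique, unknown or untested is made for them only; others in the source may bear on it.

Measured so far in an assay on isolated protein for inhibition of Leucine-rich repeat serine/threonine-protein kinase 2 (Homo sapiens), in the presence of a further agent that is not named here; a higher number here means a weaker inhibitor, a lower number a stronger inhibitor:
- compound 1 `COc1ccc(OC)c(Sc2ccc3nnc(-c4ccccn4)n3n2)c1`: 496 nM
- compound 2 `COc1ccc(OC)c(Sc2ccc3nnc(-c4cccnc4)n3n2)c1`: 242 nM
- compound 3 `COc1ccc(OC)c(Sc2ccc3nnc(C4CCN(C)C4)n3n2)c1`: 12600 nM

Compound 3 gives the highest number of the three, with a 25-fold higher number from compound 1 to compound 3 (1.40 log units; beyond the scatter) and a 52-fold higher number from compound 2 to compound 3 (1.72 log units; beyond the scatter) separating it from the two aromatic-substituted analogues, which themselves differ only by a 2.0-fold lower number from compound 1 to compound 2 (0.31 log units; beyond the scatter).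

Compound 4 `COc1ccc(OC)c(Sc2ccc3nnc(Cc4cnn(C)c4)n3n2)c1` is the next step from compound 3: (1-methyl-1H-pyrazol-4-yl)methyl in place of 1-methylpyrrolidin-3-yl on an aromatic carbon. Going by the values given here, no measured step covers this exact change. The two steps that bear on it both show that replacing an aromatic ring at this position by 1-methylpyrrolidin-3-yl raised the number strongly; compound 4 returns an aromatic ring, though through a methylene, so a lower number than compound 3 is expected, likely not reaching compound 1 or compound 2. Compound 4 is estimated at 3000 nM, range 800 nM to 12000 nM, meaning an expected 4.2-fold lower number from compound 3 to compound 4 (0.62 log units; beyond the scatter).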

Compound 4, half-maximal inhibitory concentration: 32000 nM
The estimate for compound 4 lay 11-fold (1.03 log units) below the measured number; measured number above the stated range.
By their numbers in this assay, from the lowest: compound 2; then compound 1; then compound 3; then compound 4.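

Putting an aromatic ring back through a methylene does not lower the number at this position: (1-methyl-1H-pyrazol-4-yl)methyl gives a 2.5-fold higher number from compound 3 to compound 4 (0.40 log units; beyond the scatter) and sits far from the directly attached pyridines, with a 65-fold higher number from compound 1 to compound 4 (1.81 log units; beyond the scatter) and a 130-fold higher number from compound 2 to compound 4 (2.12 log units; beyond the scatter) in these comparisons. Among these four compounds, an aromatic ring alone therefore does not secure the lower numbers. No available evidence accounts for this result. The compounds shown leave open whether the methylene or the pyrazole drives the rise. A directly attached 1-methyl-1H-pyrazol-4-yl and a pyridin-3-ylmethyl group would separate the two.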